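Shortening the Side Chain: From Compound 1 to Compound 4

The compounds below may be only part of what the source reports. "The series", "measured", "known", "first", "only" and "open" are said of these compounds alone.

For the measured compounds named here, compound 1 `CCCC(C)(C)Nc1ccc(NC(=O)c2cc(Cl)ccc2O)c(Cl)c1` is the only member of this small set that comes with a number. In an ADME assay on A549 cells (Homo sapiens) for cytotoxicity, read by LDH release, with a stated time of 15 h (a higher number here means that more compound is tolerated, a lower number that less compound is tolerated), compound 1 gives 23700 nM. Two related compounds, compound 2 `O=C(Nc1ccc(N2CCCC2)cc1Cl)c1cc(Cl)ccc1O` and compound 3 `O=C(Nc1ccc(NCc2ccc(F)cc2)cc1Cl)c1cc(Cl)ccc1O`, carry no result: in this assay compound 2 gives "not determined" (no result reported), and compound 3 gives "not determined" (no result reported). Compound 4 `CC(C)Nc1ccc(NC(=O)c2cc(Cl)ccc2O)c(Cl)c1` has not been measured. It differs from compound 1 in a single place: hydrogen in place of propyl on a saturated chain carbon bound to a nitrogen on an aromatic ring and two saturated chain carbons. Going by the values given here, no measured pair shows how removing a propyl acts in this assay, so the expectation rests on compound 1 alone. The step is expected to stay within the usual scatter, at a 1.3-fold higher number from compound 1 to compound 4 (0.10 log units; within the scatter). Compound 4 is therefore estimated at 30000 nM, with a likely range from 10000 nM to 90000 nM.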

Compound 4, half-maximal cytotoxic concentration: 82700 nM
Beside the measured number, compound 4's estimate is 2.8-fold (0.44 log units) below it; measured number inside the range.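

Going from (1,1-dimethylbutyl)amino to isopropylamino brings a 3.5-fold higher number from compound 1 to compound 4 (0.54 log units; beyond the scatter) in this assay and gives the first measured sign that this position responds to the size of the chain it carries. The step is modest, and it rests on this one pair alone. Nothing measured here accounts for the shift.

Open, as far as these compounds go, is whether a smaller group such as methyl would continue the same direction. Also open, from the compounds shown here alone, is how a chain ending in an amine or a carboxylic acid would behave at this place.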